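The compounds below may be only part of what the source reports. "The series", "measured", "known", "first", "only" and "open" are said of these compounds alone.

Compound 1, `CC(C)n1ncc2c(C(=O)NCc3ccccc3)cccc21`: in a functional assay on HepG2 cells (Homo sapiens) for inhibition, read by MTT assay, with a stated time of 72 h (a lower number here means a stronger inhibitor, a higher number a weaker inhibitor), compound 1 reached only the limit > 40000 nM.
Compound 2, `CC(C)n1ncc2c(C(=O)NCc3cn(-c4ccc(I)cc4)nn3)cccc21`: in this assay compound 2 likewise reached only the limit > 40000 nM.

Neither measurement gives a number. Both results sit at the limit of > 40000 nM in this assay, at which 2 of the 2 values shown sit, so compound 2 stands at the same place as compound 1: at the edge of what this assay can report, with no inhibition detected within that range.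

Compound 3, `CC(C)n1ncc2c(C(=O)NCc3cn(-c4ccc([N+](=O)[O-])cc4)nn3)cccc21`, is not yet measured. It differs from compound 2 in one place: nitro in place of iodo on an aromatic carbon. Within the data shown here, no step between two measured compounds exists here, so nothing in the data shows how such a change moves the number in this assay. Given that compound 2 sits at the limit of > 40000 nM in this assay, at which 2 of the 2 values shown sit, the expectation for compound 3 is no step beyond the scatter, with the result most likely again a limit. Compound 3 is expected at 50000 nM, within a range from 20000 nM to 200000 nM. The step this estimate means, a step that the limit leaves unreadable from compound 2 to compound 3, is expected to be small.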

Compound 3, half-maximal inhibitory concentration: > 40000 nM
Compound 3: only a limit was reported; the forecaster's own chance of this, stated with the estimate: 85%; the middle value does not contradict the limit.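

Compound 2 and compound 3 both give a limit rather than a number, so no step can be read for nitro in place of iodo: the limit of > 40000 nM in this assay, at which 3 of the 3 values shown sit.

The compounds shown leave open whether any structure in this series reaches a measurable inhibition in this assay.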